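A New Side Group on the Same Chain Carbon

The compounds below may be only part of what the source reports. "The series", "measured", "known", "first", "only" and "open" are said of these compounds alone.

In an ADME assay on microsomes from liver (Mus musculus) for metabolic stability, read by LC-MS, using NADPH, with stated times of 10 min and 30 min, tested at 1 uM (on this read-out higher numbers stand for fast clearance and lower numbers for slow clearance), compound 2 `COC(=O)C1=C(Cn2ccnc2)NC(c2nccs2)=NC1(C)c1ccc(F)cc1` gives 69 mL/min/kg, and compound 1 `COC(=O)C1=C(CN2CCC(O)CC2)NC(c2nccs2)=NC1(C)c1ccc(F)cc1` gives 81 mL/min/kg. For the measured compounds named here, these are the only two numbers so far, and they lie within the scatter of each other. Compound 3 `COC(=O)C1=C(CN(C)C2(C(=O)O)CC2)NC(c2nccs2)=NC1(C)c1ccc(F)cc1` keeps the shared core and changes one group: a group of 8 heavy atoms (5 carbon, 1 nitrogen, 2 oxygen; one three-membered non-aromatic ring of carbon only) in place of a group of 5 heavy atoms (3 carbon, 2 nitrogen; one five-membered aromatic ring with 2 hetero atoms), on a saturated chain carbon bound to a double-bonded ring carbon. The incoming group holds a three-membered non-aromatic ring of carbon only and sits on a saturated chain carbon bound to a double-bonded ring carbon. Going by the values given here, one measured step bears on this place: a 1.2-fold lower number from compound 1 to compound 2 (0.07 log units; within the scatter). Among the compounds with values here, that single swap stayed within the scatter, but the data hold no example of a group like the incoming one. No step beyond the scatter is therefore expected in this assay, in either direction. The expected step is a 1.4-fold lower number from compound 2 to compound 3 (0.14 log units; within the scatter). The estimated value for compound 3 is 50 mL/min/kg, with an expected range from 20 mL/min/kg to 90 mL/min/kg.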

Compound 3, clearance: 42 mL/min/kg
The estimate for compound 3 lay 1.2-fold (0.08 log units) above the measured number; the measured number falls inside the stated range.
By their numbers in this assay, from the lowest: compounds 3, 2 and 1 (each within the scatter of the next).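

In this assay, the saturated chain carbon bound to a double-bonded ring carbon now carries a third, very different group, one holding a three-membered non-aromatic ring of carbon only, and both new steps stay within the scatter (a 1.6-fold lower number from compound 2 to compound 3 (0.22 log units; within the scatter); a 1.9-fold lower number from compound 1 to compound 3 (0.29 log units; within the scatter)). An aromatic ring, a six-membered non-aromatic ring and this new group have therefore all stood at this place without a step beyond the scatter. No supporting measurement is available to explain these numbers.

The compounds shown leave open whether the three-membered ring or the rest of the incoming group matters for this read-out. Going by these compounds, a dimethylamino or morpholin-4-yl group on the same chain carbon could help separate these parts, and whether any group here can give a step beyond the scatter remains unknown.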